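The compounds below may be only part of what the source reports. "The series", "measured", "known", "first", "only" and "open" are said of these compounds alone.

Measured so far in a functional assay on LN-229 cells (Homo sapiens) for antiproliferative activity, with a stated time of 72 h; a higher number here means a weaker inhibitor, a lower number a stronger inhibitor:
- compound 1 `CCCC#Cc1cc([C@@H]2O[C@H](CO)[C@@H](O)[C@H]2O)n2ncnc(N)c12` gives 40 nM
- compound 2 `Nc1ncnn2c([C@@H]3O[C@H](CO)[C@@H](O)[C@H]3O)cc(C#Cc3ccc(F)cc3)c12` gives > 100000 nM as a limit of the assay, not a number
- compound 3 `Nc1ncnn2c([C@@H]3O[C@H](CO)[C@@H](O)[C@H]3O)cc(-c3ccc(F)cc3F)c12` gives 43500 nM

Of the two real numbers, compound 3 holds the higher one, and a 1100-fold higher number from compound 1 to compound 3 (3.04 log units; beyond the scatter) sets it far from compound 1. Compound 4 `Nc1ncnn2c([C@@H]3O[C@H](CO)[C@@H](O)[C@H]3O)cc(-c3ccsc3)c12` keeps the shared core and changes one group: thiophen-3-yl in place of 2,4-difluorophenyl on an aromatic carbon. Among the compounds with values here, two steps bear most directly on this change. Both an at least 2500-fold higher number from compound 1 to compound 2 (3.39 log units; beyond the scatter) and a 1100-fold higher number from compound 1 to compound 3 (3.04 log units; beyond the scatter) replace the chain of compound 1 with a group carrying an aromatic ring, and both are large. By comparison, an at least 2.2-fold lower number from compound 2 to compound 3 (0.36 log units; beyond the scatter) is small, though beyond the scatter. Compound 4 still carries an aromatic ring, so a return to the level of compound 1 (40 nM) is not expected. Its ring is a different kind, however, so a moderate fall is expected, with wide uncertainty. The expected change is an 8.7-fold lower number from compound 3 to compound 4 (0.94 log units; beyond the scatter) in this estimate. The estimate for compound 4 is 5000 nM with an expected range from 300 nM to 60000 nM in this assay.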

Compound 4, half-maximal inhibitory concentration: 57700 nM
Beside the measured number, compound 4's estimate is 12-fold (1.06 log units) below it, and the stated range covers the measured number.
By their numbers in this assay, from the lowest: compound 1; then compounds 3 and 4 (each within the scatter of the next). At a limit, above all of these: compound 2.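

In this assay, a 1.3-fold higher number from compound 3 to compound 4 (0.12 log units; within the scatter) shows that at this position a five-membered aromatic ring containing sulfur and a six-membered carbon ring bearing two fluorines cannot be told apart, even though the two groups differ in ring size, atoms and hydrogen-bond acceptor count. The gap to the chain-bearing compound also stays large, at a 1400-fold higher number from compound 1 to compound 4 (3.16 log units; beyond the scatter), so among the compounds shown only compound 1, with pent-1-yn-1-yl, breaks from the weak results given by the groups containing an aromatic ring. Set against a limit of the assay rather than a number, an at least 1.7-fold lower number from compound 2 to compound 4 (0.23 log units; that floor lies within the scatter) gives only a floor and settles no order.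

Going by these compounds, it remains open whether the triple bond or the open chain of compound 1 matters more, which a saturated pentyl chain could test. On these data alone, how a cyclopropyl ring or an amine would behave on this carbon also remains open.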